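A few compounds are considered here, and "the series" means these few. Any claim that something is new, unique, unknown or untested is made for them only; others in the source may bear on it.

Measured compounds:
- Compound 1, `O=C(N[C@@H](COCc1ccccc1)CN1CCc2cc(F)ccc21)O[C@@H](CC1CCCCC1)C(=O)N1CCOCC1`: 8 nM
- Compound 2, `O=C(N[C@@H](CCc1ccccc1)CNc1ccc(OC(F)(F)F)cc1)O[C@@H](CC1CCCCC1)C(=O)N1CCOCC1`: 18 nM
- Compound 3, `C[C@@H]1CN(C(=O)[C@H](CC2CCCCC2)OC(=O)N[C@@H](C)CN2CC(C)(C)c3cc(F)ccc32)C[C@H](C)O1`: 297 nM

In an assay on isolated protein for inhibition of cathepsin S (Homo sapiens) (on this read-out higher numbers stand for weaker inhibition and lower numbers for stronger inhibition), compound 3 gives the highest of the three numbers; compound 2 and compound 1 both sit well below it, beyond the scatter in each case. Compound 4, `COCCN(C)C(=O)[C@H](CC1CCCCC1)OC(=O)N[C@@H](C)CN1CC(C)(C)c2cc(F)ccc21`, keeps the core of compound 3 and changes only the amide end: (2-methoxyethyl)(methyl)amino in place of 2,6-dimethylmorpholin-4-yl on a carbonyl carbon. Among the measured compounds shown here, no measured pair shows a change of this kind, so the size of the effect is not known from the data. The author expects a small shift toward weaker inhibition, a 1.3-fold higher number from compound 3 to compound 4 (0.13 log units; within the scatter), since the ring is opened without any new donor being added. Compound 4 is therefore expected to give about 400 nM in this assay, within a range from 130 nM to 1200 nM.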

Compound 4, inhibition constant: 172 nM
For compound 4 the middle estimate is 2.3-fold (0.37 log units) above the measured one, and the stated range covers the measured number.
By their numbers in this assay, from the lowest: compound 1; then compound 2; then compounds 4 and 3 (each within the scatter of the next).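

In this assay, among the compounds shown here, (2-methoxyethyl)(methyl)amino in place of 2,6-dimethylmorpholin-4-yl on a carbonyl carbon gives a 1.7-fold lower number from compound 3 to compound 4 (0.24 log units; within the scatter), the first reading at this position. On this core, then, the ring and its two defined stereocentres can be given up without a shift beyond the scatter. No measurement shown bears on the reason for this result.

The compounds shown leave open how this position responds to a dimethylamino group or to a longer chain ending in an amine. They also leave open whether the same exchange reads alike on the core of compound 1.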